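This account rests on a few compounds, and the source may have more. Where it says the series, first, only, none or still open, it means among the compounds named here.

Measured compounds:
- In an ADME assay on HCT-116 cells (Homo sapiens) for cytotoxicity, read by MTT assay (a higher number here means that more compound is tolerated, a lower number that less compound is tolerated), compound 1 `Cc1nc(-c2cccnc2)sc1-c1nnc(Cc2ccccc2)o1` gives only a limit, > 100 ug/mL.
- In this assay compound 2 `Cc1nc(-c2cccnc2)sc1-c1nnc(-c2ccc(Br)cc2)o1` likewise gives only a limit, > 100 ug/mL.

Compound 2 thus stands at the ceiling of what this assay reports: both values shown sit at that limit (the limit of > 100 ug/mL in this assay, at which 2 of the 2 values shown sit), and no number for compound 2 itself is known. For the measured compounds named here, the one measured step, a step that the two limits leave unreadable from compound 1 to compound 2, is unreadable, as both ends of it are limits. Compound 3 `Cc1nc(-c2cccnc2)sc1-c1nnc(-c2ccccc2Cl)o1` differs from compound 2 by 2-chlorophenyl in place of 4-bromophenyl on an aromatic carbon. The measured step from compound 1 to compound 2 touches the same place on the core of compound 2, but it swaps a benzyl for a 4-bromophenyl, not one halophenyl for another, and its size is hidden behind the two limits. Nothing in the data gives a direction or a size for the exchange of a 4-bromophenyl for a 2-chlorophenyl. No movement beyond the scatter is expected in this assay. Compound 3 is therefore expected to reach the limit as well, with an estimate of 120 ug/mL, between 50 ug/mL and 300 ug/mL. That estimate means an expected step that the limit leaves unreadable from compound 2 to compound 3.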

Compound 3, half-maximal cytotoxic concentration: > 100 ug/mL
Compound 3: only a limit was reported (the forecaster's own chance of this, stated with the estimate: 80%); the middle value is on the limit's open side.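

No step among compound 1, compound 2 and compound 3 can be read in this assay, since each of the three gives only a limit: the limit of > 100 ug/mL in this assay, at which 3 of the 3 values shown sit.

The compounds shown leave open how much of each is actually tolerated, and whether the benzyl, 4-bromophenyl and 2-chlorophenyl groups differ at all in this assay.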